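The compounds below may be only part of what the source reports. "The series", "measured", "known", "first", "only" and "open" are said of these compounds alone.

In a functional assay on MCF7 cells (Homo sapiens) for antiproliferative activity, read by MTT assay, with a stated time of 48 h (a lower number here means a stronger inhibitor, a higher number a weaker inhibitor), two compounds have been measured:

Compound 1 `COc1ccc(C(=O)c2ccc(OC)c3c2C=CC(C)(C)O3)c(NC(=O)CN(C)C)c1`: 6530 nM
Compound 2 `C=C(c1ccc(OC)cc1NC(=O)CO)c1ccc(OC)c2c1OC(C)(C)C=C2`: 100 nM

Compound 2 holds the lower of these two numbers, and its gap to compound 1 lies well beyond the usual scatter of repeated measurements. Compound 3 `C=C(c1ccc(OC)cc1NC(=O)CN(C)C)c1ccc(OC)c2c1OC(C)(C)C=C2` departs from compound 2 in one place, with dimethylamino in place of hydroxy on a saturated chain carbon bound to a carbonyl carbon. Within the data shown here, no pair of measured compounds isolates this change, so the data offer no direct precedent for it. Among the measured compounds shown here, the only hint is indirect: the one measured compound bearing dimethylamino is compound 1, at 6530 nM, while the hydroxy-bearing compound 2 gives 100 nM. On that slim basis, a moderate move towards a higher number is expected in this assay, one that may only just clear the scatter, and nothing like the full gap between the two measured compounds. The estimated step is a 2.5-fold higher number from compound 2 to compound 3 (0.40 log units; beyond the scatter). For compound 3 the expected value is 250 nM, with an estimated range of 60 nM to 1500 nM.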

Compound 3, half-maximal inhibitory concentration: 500 nM
Beside the measured number, compound 3's estimate is 2.0-fold (0.30 log units) below it; measured number inside the range.
By their numbers in this assay, from the lowest: compound 2; then compound 3; then compound 1.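

Among these compounds, the pair of compound 2 and compound 3 is the first to isolate this change. In this assay, putting dimethylamino in place of hydroxy on a saturated chain carbon bound to a carbonyl carbon gives a 5.0-fold higher number from compound 2 to compound 3 (0.70 log units; beyond the scatter), a modest step that lies beyond the scatter but shows that this position accepts the tertiary amine without a collapse in the number. Among the compounds shown here, the single step cannot separate the two things that change together, since a hydrogen-bond donor leaves with hydroxy and more heavy atoms enter with dimethylamino. Nothing in the data shown gives a reason for this step.

What the compounds shown leave open is whether hydroxy itself is what favours compound 2, a question that a methoxy group, a primary amine or a carboxylic acid on the same chain carbon, or a longer chain ending in hydroxy, would help to answer. They also leave open whether the same change would give a step of similar size on the core of compound 1, since no hydroxy partner for that compound is shown.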